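A few compounds are considered here, and "the series" means these few. Any claim that something is new, unique, unknown or untested is made for them only; others in the source may bear on it.

Measured so far:
- Compound 1 `COc1ccc(F)cc1CNCCCNc1ccnc2cc(Cc3ccc(C#N)cc3)ccc12`: 4200 nM
- Compound 2 `FC(F)(F)c1ccc(-c2ccc3c(NCCCNCc4ccco4)ccnc3c2)cc1`: 32000 nM
- Compound 3 `COc1ccccc1Oc1ccc2c(NCCCNCc3ccco3)ccnc2c1`: 14500 nM

In a physicochemical assay for solubility, with a stated time of 18 h, at pH 7.4 (a higher number here means a more soluble compound, a lower number a less soluble compound), compound 1 gives 4200 nM, the lowest of the three numbers; its nearest neighbour, compound 3, stands at 14500 nM, and compound 2 at 32000 nM. For the measured compounds named here, the one measured step between compounds that differ in a single place, a 2.2-fold lower number from compound 2 to compound 3 (0.34 log units; beyond the scatter), concerns a group on an aromatic carbon of the shared core, not the part of the molecule changed here.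

Compound 4 `COc1ccc(F)cc1CNCCCNc1ccnc2cc(CC3CCCCC3)ccc12` is not yet measured. It differs from compound 1 in this way: cyclohexyl in place of 4-cyanophenyl on a saturated chain carbon bound to an aromatic carbon. Going by the values given here, no measured pair shows this change, or any change at a saturated chain carbon bound to an aromatic carbon, so there is no direct guide to its size or direction; the one measured step only shows that a single swap at one place can move this assay by a modest amount beyond the scatter. The number for compound 4 is therefore estimated to stay close to that of compound 1, with the expected step of a 1.4-fold lower number from compound 1 to compound 4 (0.15 log units; within the scatter) small and possibly within the scatter. The estimate for compound 4 is 3000 nM, with a range from 1000 nM to 9000 nM.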

Compound 4, solubility: 4200 nM
Beside the measured number, compound 4's estimate is 1.4-fold (0.15 log units) below it; the measured number falls inside the stated range.
By their numbers in this assay, from the lowest: compounds 1 and 4 (each within the scatter of the next); then compound 3; then compound 2.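

For the compounds shown here, the swap of 4-cyanophenyl for cyclohexyl on a saturated chain carbon bound to an aromatic carbon gives no change at the digits printed from compound 1 to compound 4 (within the scatter) in this assay and is the first measured change at this position. The group that leaves has 8 heavy atoms, an aromatic ring, a triple bond and 1 hydrogen-bond acceptor, while the group that enters has 6 heavy atoms, a non-aromatic ring and 0 hydrogen-bond acceptors, so in this one pair these differences in the group come with no measurable shift in the read-out. Nothing measured here explains why the two compounds read alike.

Both groups shown at this position are six-membered rings of carbon with no net charge on the ring group, and a single pair cannot show whether the same holds for other groups there. As far as these compounds go, what an amine or a carboxylic acid on the ring, or a longer chain in place of the saturated chain carbon, would do to this number remains open.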